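Terminal amine added to the linker of a lipopeptide agonist

A few compounds are considered here, and "the series" means these few. Any claim that something is new, unique, unknown or untested is made for them only; others in the source may bear on it.

Compound 1, `CCCCCCCCCCCCCC(=O)OC[C@H](CSC[C@H](N)C(=O)N[C@@H](CO)C(=O)O)OC(=O)CCCCCCCCCCCCC`, and compound 2, `CCCCCCCCCCCCCCCC(=O)O[C@H](COC(=O)CNCCCOCCOCCOCC)CSC[C@H](N)C(=O)N[C@@H](CO)C(=O)O`, were tested in a functional assay on HEK293 cells for agonist activity at Toll-like receptor 2 (Homo sapiens), read by spectrophotometry, with a stated time of 12 h; on this read-out lower numbers stand for an effect already at smaller amounts and higher numbers for an effect only at larger amounts of compound. Compound 1 gives 0.56 nM, and compound 2 gives 2.11 nM, the higher of the two numbers. Compound 3, `CCCCCCCCCCCCCCCC(=O)O[C@H](COC(=O)CNCCCOCCOCCOCCCN)CSC[C@H](N)C(=O)N[C@@H](CO)C(=O)O`, has not yet been measured. It differs from compound 2 by aminomethyl in place of hydrogen on a saturated chain carbon, two bonds along the chain from an oxygen on a saturated carbon. With only these two earlier results to go on, the step from compound 2 to compound 3 in this assay is expected to be small, a 1.1-fold lower number from compound 2 to compound 3 (0.02 log units; within the scatter), not beyond the usual scatter. Compound 3 is therefore expected to give about 2 nM, within 0.7 nM to 6 nM.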

Compound 3, half-maximal effective concentration: 1.55 nM
Beside the measured number, compound 3's estimate is 1.3-fold (0.11 log units) above it, and the stated range covers the measured number.
By their numbers in this assay, from the lowest: compound 1; then compounds 3 and 2 (each within the scatter of the next).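

In this assay, aminomethyl can take the place of hydrogen on this saturated chain carbon, two bonds along the chain from an oxygen on a saturated carbon, with a 1.4-fold lower number from compound 2 to compound 3 (0.13 log units; within the scatter). At this place, then, a chain ending in an amine and one without it cannot be told apart on this read-out. Nothing shown here offers an explanation for this result.

The compounds shown carry only hydrogen or aminomethyl at this place. As far as these compounds go, what a carboxylic acid or a longer chain ending in an amine would give there remains open.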